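Changing the aromatic ring on the ring amine nitrogen

A few compounds are considered here, and "the series" means these few. Any claim that something is new, unique, unknown or untested is made for them only; others in the source may bear on it.

Compound 1, `CC1(c2ccccc2)CC(=O)N(CC(=O)N2CCN(c3ccccc3F)CC2)C1=O`: 100 mg/kg
Compound 2, `CC1(c2ccccc2)CC(=O)N(CC(=O)N2CCN(c3ccc(Cl)cc3)CC2)C1=O`: "not active" (no number reported)

In a functional assay on the whole organism (strain CD-1) with Mus musculus as the target, in the maximal electroshock model, with a stated time of 0.5 h (on this read-out higher numbers stand for an effect only at larger amounts of compound and lower numbers for an effect already at smaller amounts), compound 1 gives 100 mg/kg, while compound 2 is reported only as "not active" (no number reported), so no single number stands for compound 2 and its position can only be described as a compound without a recorded dose. Compound 3, `Cc1cccc(N2CCN(C(=O)CN3C(=O)CC(C)(c4ccccc4)C3=O)CC2)c1`, keeps the whole shared core and differs from compound 2 in one place: 3-methylphenyl in place of 4-chlorophenyl on an amine nitrogen in a ring. Among the compounds with values here, with no recorded number for compound 2, no step can be counted, and the expectation for compound 3 can rest only on compound 1, whose dose of 100 mg/kg shows what this core can reach in this assay. The estimate for compound 3 is therefore expected near that level, at 100 mg/kg, within the range 30 mg/kg to 300 mg/kg, with a real chance that, like compound 2, only an absence of activity is recorded.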

Compound 3, minimum effective dose: 100 mg/kg
Compound 3: middle estimate and measured number agree at the digits printed; low and high end bracket the measured number.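

In this assay, replacing 2-fluorophenyl with 3-methylphenyl on the amine nitrogen in the ring gives no change at the digits printed from compound 1 to compound 3 (within the scatter), so a recorded dose on the shared core does not depend on the fluorine. Compound 3 has a recorded dose, while compound 2, with 4-chlorophenyl at the same place, is reported only as not active; the size of that step cannot be read, as one side has no number. Nothing measured here explains why these aromatic groups differ in outcome.

The compounds shown leave open whether the outcome of compound 2 goes with the chlorine itself or with the place it holds on the phenyl ring, which 3-chlorophenyl and 4-methylphenyl groups could help separate. They also leave open how plain phenyl or a pyridine ring would read out at this position.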